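Opening the Ring: From Compound 1 to Compound 4

The source may hold more compounds than are shown below. What is called first, only, known or untested is meant among the compounds shown, and "the series" means these compounds.

Compound 1, `O=C(O)CC1CCCC1Cc1ccc(OCc2ccc3ccccc3n2)cc1`: 100 nM
Compound 2, `CCCC(CCc1nnn[nH]1)Cc1cccc(OCc2ccc3ccccc3n2)c1`: 11 nM
Compound 3, `CC(CCc1cccc(OCc2ccc3ccccc3n2)c1)Cc1nnn[nH]1`: 17 nM

Of the compounds shown here, three have so far been tested in an assay on membranes from lung (Cavia porcellus) for binding affinity to cysteinyl leukotriene receptor (Homo sapiens); a lower number here means a stronger inhibitor, a higher number a weaker inhibitor. Compound 1 stands with the highest number of the three. Its nearest neighbour is compound 3, and the gap between them lies beyond the usual scatter; the gap to compound 2 is wider still. Compounds 2 and 3 share the core of compound 1 but differ from it in several places at once, so their values show only that both are stronger inhibitors, not which single change is responsible.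

Compound 4, `O=C(O)CCCCc1ccc(OCc2ccc3ccccc3n2)cc1`, has not yet been measured. It differs from compound 1 in one place: 3-carboxypropyl in place of 2-(carboxymethyl)cyclopentyl on a saturated chain carbon bound to an aromatic carbon. The five-membered ring is gone and a short open chain carries the acid instead.

Among the compounds with values here, no measured pair shows a step of this kind, so the expectation rests on compound 1 alone, whose result in this assay is 100 nM. The step of a 3.0-fold higher number from compound 1 to compound 4 (0.48 log units; beyond the scatter) is expected to be a moderate weakening, somewhat beyond the scatter. Compound 4 is therefore estimated at 300 nM, with a range from 80 nM to 1500 nM.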

Compound 4, inhibition constant: 110 nM
Compound 4: the middle estimate sits 2.7-fold (0.44 log units) above what was measured; the measured number falls inside the stated range.
By their numbers in this assay, from the lowest: compounds 2 and 3 (each within the scatter of the next); then compounds 1 and 4 (each within the scatter of the next).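

Swapping 2-(carboxymethyl)cyclopentyl for 3-carboxypropyl, on a saturated chain carbon bound to an aromatic carbon, gives a 1.1-fold higher number from compound 1 to compound 4 (0.04 log units; within the scatter) in this assay, so this assay does not tell the two compounds apart. At this position, then, the five-membered ring of carbon only can give way to an open chain, and the group can go from 9 heavy atoms to 6, with no measurable cost in this pair; the acid stays in both groups, so this pair says nothing about its role. Within the data shown here, the earlier compounds could not show this, as they differ from one another in several places at once, whereas compound 1 and compound 4 form the only pair here that isolates one change.

The compounds shown leave open how a longer chain carrying the carboxylic acid, or a primary amide in place of that acid, would behave at this position in this assay. No supporting measurement here bears on why the open chain and the ring give matching results.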